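A few compounds are considered here, and "the series" means these few. Any claim that something is new, unique, unknown or untested is made for them only; others in the source may bear on it.

In a functional assay on HL-60 cells (Homo sapiens) for inhibition, read by CCK-8 assay, with a stated time of 48 h, tested at 20 uM (on this read-out higher numbers stand for more inhibition of growth at the one concentration tested and lower numbers for less inhibition of growth), three compounds share one core and differ only in the group on the sulfonyl sulfur. Compound 1 (`N#C/C(=C\c1ccccc1OS(=O)(=O)c1ccc([N+](=O)[O-])cc1)C(=O)Nc1nnc(Cc2ccccc2)s1`) gives 20%, compound 2 (`N#C/C(=C\c1ccccc1OS(=O)(=O)c1ccccc1[N+](=O)[O-])C(=O)Nc1nnc(Cc2ccccc2)s1`) gives 12%, and compound 3 (`N#C/C(=C\c1ccccc1OS(=O)(=O)c1ccc(Cl)cc1)C(=O)Nc1nnc(Cc2ccccc2)s1`) gives 26%. Compound 3 has the highest of these three numbers, but the data show a number 6 percentage points higher from compound 1 to compound 3 (within the scatter), set against a number 14 percentage points higher from compound 2 to compound 3 (beyond the scatter). The remaining pair shows a number 8 percentage points lower from compound 1 to compound 2 (within the scatter).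

Compound 4 (`Cc1ccc(Cc2nnc(NC(=O)/C(C#N)=C/c3ccccc3OS(=O)(=O)c3ccc(Cl)cc3)s2)cc1`) keeps the sulfonyl side of compound 3 and changes benzyl to 4-methylbenzyl, with methyl in place of hydrogen on an aromatic carbon. For the measured compounds named here, none of the measured steps touches the benzyl group, so they offer no direct guide to this change. They show only how far the numbers have moved within this small set, and the largest of them is modest. No step beyond the scatter is therefore expected in this assay, and the estimated step is no change at the digits printed from compound 3 to compound 4 (within the scatter). For compound 4 the estimate is 26%, with an expected range from 13% to 42%.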

Compound 4, percent growth inhibition at one concentration: 38%
The estimate for compound 4 lay 12 percentage points below the measured number, within the range that was stated.
By their numbers in this assay, from the lowest: compounds 2, 1 and 3 (each within the scatter of the next, the first and the last beyond it); then compound 4.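

The earlier compounds shown here differ only in the group on the sulfonyl sulfur, so they say nothing about the benzyl group. In this assay, changing benzyl to 4-methylbenzyl adds just one carbon and gives a number 12 percentage points higher from compound 3 to compound 4 (beyond the scatter), so this position, on a six-membered aromatic ring and para to a large group, does respond to a very small change. Nothing measured here explains why this methyl group raises the number.

On these data alone, whether an ethyl group, a methoxy group or an amine in place of this methyl would move the number further remains open. It is also unknown whether the methyl step would hold with the 4-nitrophenyl group of compound 1 on the sulfonyl sulfur, since only one such pair is shown.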